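A larger amide substituent on a weakly active core

The compounds below may be only part of what the source reports. "The series", "measured", "known", "first", "only" and "open" are said of these compounds alone.

Compound 1 `CSCNC(=O)c1ccc(NCc2cncn2Cc2ccc(C#N)cc2)cc1-c1ccccc1` carries a small amide on the shared core. In a functional assay on NIH3T3 cells (Mus musculus) (on this read-out higher numbers stand for an effect only at larger amounts of compound and lower numbers for an effect already at smaller amounts), compound 1 gives > 10 uM, a limit of the assay rather than a number. Two relatives are known. Compound 2 `COC(=O)[C@H](CCSC)NC(=O)c1ccc(NCc2cncn2Cc2cccc(C#N)c2)cc1-c1ccccc1` gives > 10 uM in this assay, again only a limit. Compound 3 `COC(=O)[C@H](CCSC)NC(=O)c1ccc(CNCc2c[nH]cn2)cc1-c1ccccc1C` gives 25 uM in this assay. Compound 1 thus sits at the limit of > 10 uM in this assay, at which 2 of the 3 values shown sit, where most of the results gathered here lie.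

Compound 4 `N#Cc1ccc(Cn2cncc2CNc2ccc(C(=O)Nc3cccc(C#N)c3)c(-c3ccccc3)c2)cc1` differs from compound 1 in one place: 3-cyanophenyl in place of (methylsulfanyl)methyl on an amide-type nitrogen. Among the measured compounds shown here, no measured pair shows the effect of such a change, so its direction cannot be read from the data. The expected step is therefore modest, an at least 1.2-fold lower number from compound 1 to compound 4 (0.09 log units; that floor lies within the scatter). Compound 4 is expected to give about 8 uM, within a range from 1.5 uM to 40 uM.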

Compound 4, concentration for half-maximal effect: > 10 uM
Compound 4: no number, only a limit; the forecaster's own chance of this, stated with the estimate: 45%; at least 1.2-fold (0.09 log units) between middle value and limit.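

In this assay, compound 1 and compound 4 each give only a limit rather than a number, so no step can be read between them. The compounds shown leave open whether 3-cyanophenyl in place of (methylsulfanyl)methyl changes the result at all.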